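Oxazole for thiazole: an expected change in maximal response

The source may hold more compounds than are shown below. What is called first, only, known or untested is meant among the compounds shown, and "the series" means these compounds.

Measured so far:
Compound 1 `c1cc(-c2nccs2)c2c(c1)C(c1ncc[nH]1)CC2`: 64%
Compound 2 `CS(=O)(=O)Nc1cccc2c1CCCC2c1ncc[nH]1`: 47%; 79%; 79% (3 entries)
Compound 3 `c1ccc2c(c1)CCCC2c1ncc[nH]1`: 71%

In a functional assay on CHO cells for agonist activity at Alpha-1A adrenergic receptor (Homo sapiens), read by FLIPR and calcium flux (on this read-out lower numbers stand for smaller maximal responses and higher numbers for larger maximal responses), compound 1 stands at 64%. Compound 3 reaches 71%, which lies within the usual scatter of that value, and compound 2 has no single number, only (the several entries of compound 2 in this assay, 47%; 79%; 79% (3 entries)). Compound 4 `c1cc(-c2ncco2)c2c(c1)C(c1ncc[nH]1)CC2` differs from compound 1 by 1,3-oxazol-2-yl in place of 1,3-thiazol-2-yl on an aromatic carbon. Going by the values given here, no measured pair differs in the same way, so the size of this step is not yet known from the data; the change keeps the ring size and the count of donors and acceptors, and in this assay a step no larger than the scatter, in either direction, is expected. Compound 4 is thus expected to give 65%, between 45% and 85%, a step of a number 1 percentage points higher from compound 1 to compound 4 (within the scatter).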

Compound 4, largest response reached (Emax), in percent of the reference or control that the assay uses: 63%
Beside the measured number, compound 4's estimate is 2 percentage points above it, and the stated range covers the measured number.
By their numbers in this assay, from the lowest: compounds 4, 1 and 3 (each within the scatter of the next).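

Going by these compounds alone, exchanging the 1,3-thiazol-2-yl group for a 1,3-oxazol-2-yl group on the shared core gives the only step known at this place in this assay, a number 1 percentage points lower from compound 1 to compound 4 (within the scatter). Within this pair, the read-out therefore does not separate the two rings, which differ by oxygen in place of sulfur. A step of this size cannot be told from the spread of repeat entries in this assay: the several entries of compound 2 in this assay, 47%; 79%; 79% (3 entries)

The compounds shown leave open whether an amine, a carboxylic acid or a phenyl ring at this place would change the maximal response. As far as these compounds go, whether the same exchange gives so small a step on another core also stays open.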